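This account rests on a few compounds, and the source may have more. Where it says the series, first, only, none or still open, it means among the compounds named here.

Measured in an ADME assay on BJ cells (Homo sapiens), read by MTT assay, with a stated time of 72 h; a higher number here means a weaker inhibitor, a lower number a stronger inhibitor:
- compound 1 `CSc1ncnc2c1c(-c1ccoc1)cn2[C@@H]1O[C@H](CO)[C@@H](O)[C@H]1O`: 98800 nM
- compound 2 `C#Cc1cn([C@@H]2O[C@H](CO)[C@@H](O)[C@H]2O)c2ncnc(NC)c12`: 86000 nM
- compound 3 `CN(C)c1ncnc2c1c(-c1ccoc1)cn2[C@@H]1O[C@H](CO)[C@@H](O)[C@H]1O`: 99200 nM

All three values lie within the scatter of one another, so compound 3, at 99200 nM, cannot be told apart from compound 1 or compound 2. The next compound to consider is compound 4 `C#Cc1cn([C@@H]2O[C@H](CO)[C@@H](O)[C@H]2O)c2ncnc(N(C)C)c12`, which comes from compound 3 by putting ethynyl in place of furan-3-yl on an aromatic carbon.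

Among the measured compounds shown here, no measured step makes this exact exchange. For the measured compounds named here, the only step available, a 1.0-fold higher number from compound 1 to compound 3 (0.00 log units; within the scatter), changes a different group, dimethylamino in place of methylsulfanyl, and shows no change beyond the scatter. The closest evidence is compound 2, which already carries ethynyl and gives 86000 nM, within the scatter of the two compounds that carry furan-3-yl. Going by the values given here, nothing measured so far therefore points to a real shift in this assay, in either direction, when ethynyl enters.

The expected change is a 1.2-fold lower number from compound 3 to compound 4 (0.09 log units; within the scatter), which would be no step beyond the scatter. For compound 4 the estimated value is 80000 nM, with an expected range from 30000 nM to 110000 nM.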

Compound 4, half-maximal inhibitory concentration: 410 nM
Compound 4: the middle estimate sits 200-fold (2.29 log units) above what was measured; measured number outside the range, below it.
By their numbers in this assay, from the lowest: compound 4; then compounds 2, 1 and 3 (each within the scatter of the next).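

In this assay, ethynyl in place of furan-3-yl on this aromatic carbon gives a 240-fold lower number from compound 3 to compound 4 (2.38 log units; beyond the scatter), so this position can matter greatly, even though the ethynyl compound 2 had sat within the scatter of the furan-3-yl compounds. Adding one methyl to the nitrogen of compound 2 gives a 210-fold lower number from compound 2 to compound 4 (2.32 log units; beyond the scatter), whereas dimethylamino in place of methylsulfanyl, with furan-3-yl kept, gives only a 1.0-fold higher number from compound 1 to compound 3 (0.00 log units; within the scatter), so the effect of a change in one place depends on the group held in the other, and among these compounds the low number appears only where ethynyl and dimethylamino occur together. Nothing measured here explains why this pairing stands apart.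

On these data alone, whether the triple bond itself is required remains open, and a nitrile or an ethyl group on the same aromatic carbon, paired with dimethylamino, would address that question. As far as these compounds go, it is also open how much room there is on the nitrogen, which a diethylamino group alongside ethynyl would help to show.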